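This account rests on a few compounds, and the source may have more. Where it says the series, first, only, none or still open, it means among the compounds named here.

Three compounds share one core and one benzyl ester, differing only in the side chain on the saturated chain carbon. Compound 1 `CC[C@@H](C)[C@H](NC(=O)c1cc2ccccc2cn1)C(=O)OCc1ccccc1` gives 96.4 nM in a functional assay on HL-60 cells (Homo sapiens) for antiproliferative activity, read by MTT assay, with a stated time of 48 h; on this read-out higher numbers stand for weaker inhibition and lower numbers for stronger inhibition. Compound 2 `O=C(N[C@@H](CO)C(=O)OCc1ccccc1)c1cc2ccccc2cn1` gives 70.4 nM, and compound 3 `NCCCC[C@H](NC(=O)c1cc2ccccc2cn1)C(=O)OCc1ccccc1` gives 68.2 nM. Compound 3 carries the low end of the three numbers, yet a 1.4-fold lower number from compound 1 to compound 3 (0.15 log units; within the scatter) and a 1.0-fold lower number from compound 2 to compound 3 (0.01 log units; within the scatter), so nothing here separates the three side chains.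

Compound 4 `O=C(C[C@H](NC(=O)c1cc2ccccc2cn1)C(=O)OCc1ccccc1)OCc1ccccc1` is not yet measured. It differs from compound 3 by benzyloxycarbonyl in place of 3-aminopropyl on a saturated chain carbon, two bonds along the chain from an amide-type nitrogen and a carbonyl carbon. For the measured compounds named here, the steps that bear on it are the earlier exchanges at this same position: a 1.4-fold lower number from compound 1 to compound 2 (0.14 log units; within the scatter), a 1.4-fold lower number from compound 1 to compound 3 (0.15 log units; within the scatter) and a 1.0-fold lower number from compound 2 to compound 3 (0.01 log units; within the scatter). None of them moved the number beyond the scatter, and the new group enters at the same place, so no step beyond the scatter is expected in this assay. Compound 4 is therefore estimated at 75 nM, with a range from 30 nM to 190 nM. That estimate means an expected 1.1-fold higher number from compound 3 to compound 4 (0.04 log units; within the scatter).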

Compound 4, half-maximal inhibitory concentration: 74 nM
Compound 4: the middle estimate sits 1.0-fold (0.01 log units) above what was measured; the range from low to high includes it.
By their numbers in this assay, from the lowest: compounds 3, 2, 4 and 1 (each within the scatter of the next).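

In this assay, the benzyloxycarbonyl group puts a six-membered aromatic ring on this side chain, which none of the earlier side chains carried, and the number still stays within the scatter: a 1.1-fold higher number from compound 3 to compound 4 (0.04 log units; within the scatter), a 1.1-fold higher number from compound 2 to compound 4 (0.02 log units; within the scatter) and a 1.3-fold lower number from compound 1 to compound 4 (0.11 log units; within the scatter). The flat picture from compound 1, compound 2 and compound 3 therefore extends to a group with more heavy atoms than 3-aminopropyl, at the same saturated chain carbon. Nothing available explains why the number holds across these four side chains.

Going by these compounds, it remains open whether a free carboxylic acid in place of the benzyloxycarbonyl group, or a longer chain carrying the same ring, would also stay within the scatter. On these data alone, the benzyl ester and the shared core are the same in all four compounds, so what either contributes to the number remains unknown.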